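The source may report more compounds than this note shows. Statements on the series, on what has been measured and on what is new or still open speak of the compounds shown alone.

Measured in a functional assay on MCF7 cells (Homo sapiens) for inhibition, read by MTT assay, with a stated time of 48 h, tested at 10 uM; on this read-out higher numbers stand for more inhibition of growth at the one concentration tested and lower numbers for less inhibition of growth:
compound 1 `Cc1oc2c([C@H]3CCN(C)C[C@H]3O)c(O)cc(O)c2c(=O)c1C(O)c1ccc([N+](=O)[O-])cc1`: 4%
compound 2 `Cc1oc2c([C@H]3CCN(C)C[C@H]3O)c(O)cc(O)c2c(=O)c1C(O)c1ccc(Cl)cc1`: 6%
compound 3 `Cc1oc2c([C@H]3CCN(C)C[C@H]3O)c(O)cc(O)c2c(=O)c1C(O)c1ccc(F)c(Br)c1`: 14%

Compound 3, at 14%, cannot be separated from the other two compounds, since both of its steps stay within the scatter. Next in the series is compound 4 `Cc1oc2c([C@H]3CCN(C)C[C@H]3O)c(O)cc(O)c2c(=O)c1C(O)c1c(Cl)cccc1Cl`, with 2,6-dichlorophenyl in place of 3-bromo-4-fluorophenyl on a saturated chain carbon bound to an aromatic carbon and an oxygen on a saturated carbon.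

Among the compounds with values here, three measured steps bear on this change, each an exchange within the same group at that place. They are a number 2 percentage points higher from compound 1 to compound 2 (within the scatter), a number 10 percentage points higher from compound 1 to compound 3 (within the scatter) and a number 8 percentage points higher from compound 2 to compound 3 (within the scatter). None of them leaves the scatter, so this assay has not yet separated any two of these groups. Within the data shown here, no measured compound carries 2,6-dichlorophenyl, and the series therefore gives no direct reading for it. No step beyond the scatter is expected, and the estimate sits among the three measured values rather than at compound 3 alone. The expected step is a number 6 percentage points lower from compound 3 to compound 4 (within the scatter). For compound 4 the estimated value is 8%, with an expected range of 0% to 20%.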

Compound 4, percent growth inhibition at one concentration: 33%
Compound 4: the middle estimate sits 25 percentage points below what was measured, outside the stated range (above it).
By their numbers in this assay, from the lowest: compounds 1, 2 and 3 (each within the scatter of the next); then compound 4.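

In this assay, the place on a saturated chain carbon bound to an aromatic carbon and an oxygen now separates compounds: 2,6-dichlorophenyl gives a number 19 percentage points higher from compound 3 to compound 4 (beyond the scatter), a number 27 percentage points higher from compound 2 to compound 4 (beyond the scatter) and a number 29 percentage points higher from compound 1 to compound 4 (beyond the scatter), while the exchanges among 4-nitrophenyl, 4-chlorophenyl and 3-bromo-4-fluorophenyl all stayed within the scatter. The step from 3-bromo-4-fluorophenyl is not accompanied by any change in heavy-atom count, ring type, hydrogen-bond donors, hydrogen-bond acceptors or net charge, so the two groups differ only in their halogens and in how these are arranged on the ring. No measured evidence accounts for this step.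

With compound 4 the only example of its kind, the shown compounds cannot separate the contribution of the two chlorines from that of their arrangement, and it remains open whether methyl in place of chlorine, or a pyridine ring in place of the phenyl ring, would keep the step. As far as these compounds go, it also remains open whether the step holds beyond the one concentration tested, since a single percent growth inhibition gives no concentration-response curve.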